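The compounds below may be only part of what the source reports. "The series", "measured", "known", "first", "only" and "open" are said of these compounds alone.

Measured so far in an assay on isolated protein for inhibition of NUAK family SNF1-like kinase 2 (Homo sapiens), read by ADP-Glo, with a stated time of 60 min, tested at 10 uM, in the presence of a further agent that is not named here; on this read-out lower numbers stand for less inhibition and higher numbers for more inhibition at the one concentration tested (going by the name of the read-out):

- compound 1, `CCC(=O)Nc1cccc(Oc2nc(Nc3ccc(N(C)C)cc3OC)ncc2Cl)c1`, gives 15%
- compound 2, `CCC(=O)Nc1cccc(Oc2ccnc(Nc3ccc(N4CCN(C)CC4)cc3)n2)c1`, gives 48.8%
- compound 3, `CCC(=O)Nc1cccc(Oc2nc(Nc3ccc(N4CCCC4)cc3OC)ncc2Cl)c1`, is recorded as "not active" (no number reported) with no number

Compound 1 stands lowest of the two compounds with a number in this assay. Its nearest neighbour is compound 2, whose reading lies higher by a margin that is beyond the usual scatter. Compound 3 carries no number at all, only a report of no activity, so nothing more than that can be read from it. Among the compounds with values here, no two measured compounds differ in one place, so no single step has been quantified in this set.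

Compound 4, `CCC(=O)Nc1cccc(Oc2nc(Nc3ccc(N(C)C)cc3)ncc2Cl)c1`, is not yet measured. It differs from compound 1 in one place: hydrogen in place of methoxy on an aromatic carbon. The methoxy leaves from an aromatic carbon that is ortho to a large group and meta to a dimethylamino group, and a hydrogen enters there.

Within the data shown here, with no quantified step from any pair, the size of the change is open. The expectation is a step from compound 1 to compound 4 of a number 7 percentage points higher from compound 1 to compound 4 (within the scatter), that is little beyond the scatter, leaning slightly upward. Compound 4 is therefore estimated at 22%, within 5% to 45%.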

Compound 4, a percentage reported as inhibition, at one concentration (the size of the read-out at that concentration, not a potency): 31.7%
For compound 4 the middle estimate is 9.7 percentage points below the measured one; the range from low to high includes it.
By their numbers in this assay, from the lowest: compound 1; then compound 4; then compound 2.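

In this assay, the series now has its first quantified single-place change: hydrogen in place of methoxy gives a number 16.7 percentage points higher from compound 1 to compound 4 (beyond the scatter), a modest step but one beyond the scatter. This shows that the reading responds to what sits on this aromatic carbon, ortho to a large group and meta to a dimethylamino group, and that the methoxy is not needed for the inhibition seen here, since the compound with hydrogen reads higher. Nothing measured in this set accounts for the size or direction of the step, so it stands as an observation only.

As far as these compounds go, with only hydrogen and methoxy compared on this carbon, it remains open how a fluorine atom, an ethoxy group or a small amine there would read in this assay, and so whether the trend depends on the size of the group or on something specific to the methoxy. From the compounds shown here alone, it is also open whether the same step would appear with another group in place of the dimethylamino group, and, as each reading comes from a single concentration, how the step would translate into potency.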